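Replacing a piperidinyl ester with a thienyl sulfide

A few compounds are considered here, and "the series" means these few. Any claim that something is new, unique, unknown or untested is made for them only; others in the source may bear on it.

For the measured compounds named here, compound 2, `COC(=O)CC1CCN(C[C@H]2CN(c3ccc(-n4cc(-c5ccccn5)cn4)c(F)c3)C(=O)O2)CC1`, is the one member of this small set with a number rather than a limit: in an ADME assay on HEK293-A cells (Homo sapiens) for cytotoxicity, read by MTT assay, with a stated time of 48 h (on this read-out lower numbers stand for stronger inhibition and higher numbers for weaker inhibition), compound 2 gives 224 ug/mL. Compound 1, `O=C1O[C@@H](CO)CN1c1ccc(-n2cc(-c3ccccn3)cn2)c(F)c1`, reaches only the limit of the assay in this assay, > 400 ug/mL. Compound 3, `O=C1CCC(=O)N1C[C@H]1CN(c2ccc(-n3cc(-c4ccccn4)cn3)c(F)c2)C(=O)O1`, likewise sits at a limit in this assay, > 400 ug/mL. The change to compound 4, `O=C1O[C@@H](CSc2cccs2)CN1c1ccc(-n2cc(-c3ccccn3)cn2)c(F)c1`, is (thiophen-2-yl)sulfanyl in place of 4-((methoxycarbonyl)methyl)piperidin-1-yl on a saturated chain carbon bound to a saturated ring carbon. Going by the values given here, two measured steps bear on it, both exchanging the same piperidinyl group at the same place: an at least 1.7-fold lower number from compound 1 to compound 2 (0.25 log units; that floor lies within the scatter) and an at least 1.7-fold higher number from compound 2 to compound 3 (0.25 log units; that floor lies within the scatter). Each shift away from the piperidinyl ester moved the read-out to the limit (the limit of > 400 ug/mL in this assay, at which 2 of the 3 values shown sit), though both floors lie within the scatter. Compound 4 is therefore expected to move in the same direction, by a 1.6-fold higher number from compound 2 to compound 4 (0.19 log units; within the scatter), with a fair chance that only a limit is reported. The estimate for compound 4 in this assay is 350 ug/mL, in a range from 150 ug/mL to 600 ug/mL.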

Compound 4, half-maximal inhibitory concentration: > 400 ug/mL
Compound 4 ended at the assay's limit; the forecaster's own chance of this, stated with the estimate: 50%; middle value at least 1.1-fold (0.05 log units) from the limit.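

Exchanging 4-((methoxycarbonyl)methyl)piperidin-1-yl for (thiophen-2-yl)sulfanyl on this saturated chain carbon gives an at least 1.7-fold higher number from compound 2 to compound 4 (0.25 log units; that floor lies within the scatter) in this assay. For the compounds shown here, a group with a five-membered aromatic ring and two sulfur atoms now joins hydroxy and 2,5-dioxopyrrolidin-1-yl at the same limit, leaving compound 2 as the one compound in the set with a number: the limit of > 400 ug/mL in this assay, at which 3 of the 4 values shown sit. The steps among compounds 1, 3 and 4 cannot be read, so these three cannot be ranked against each other.

Going by these compounds, how far any of these three lies past the limit stays open, and the only readable floors still lie within the scatter. Also open, on these data alone, is whether the piperidine ring or its methyl ester goes with the lower number, which a plain piperidin-1-yl or a carboxylic acid in place of that ester could address.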